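From Butyl to Thiophen-3-yl on the Shared Core

This account rests on a few compounds, and the source may have more. Where it says the series, first, only, none or still open, it means among the compounds named here.

Of the compounds shown here, two have been measured so far in a functional assay on MCF7 cells (Homo sapiens) for inhibition, read by fluorescence, with a stated time of 72 h; a higher number here means a weaker inhibitor of growth, a lower number a stronger inhibitor of growth. Compound 1 `CCCCc1cc2nn(-c3ccccc3)cc2c(C(C)C)n1` gives 33300 nM in this assay, while compound 2 `CCCCc1cc2nn(-c3ccccc3)cc2cn1` gives 13300 nM. Among the measured compounds shown here, the one step between them, a 2.5-fold lower number from compound 1 to compound 2 (0.40 log units; beyond the scatter), is the only change in the set, and it leaves compound 2 with the lowest of the two numbers, with compound 1 as its nearest neighbour.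

Compound 3 `c1ccc(-n2cc3cnc(-c4ccsc4)cc3n2)cc1` has not yet been measured. It differs from compound 2 by thiophen-3-yl in place of butyl on an aromatic carbon. For the measured compounds named here, no measured step bears on this kind of change: the single step known swaps an isopropyl for hydrogen elsewhere on the core, and its modest size says little about an aromatic ring replacing a butyl chain. In this assay, then, a step of no clear direction is expected for compound 3, and the estimate a 1.3-fold lower number from compound 2 to compound 3 (0.12 log units; within the scatter) is held close to the scatter. The expected value for compound 3 is therefore 10000 nM, within a range from 3000 nM to 40000 nM.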

Compound 3, concentration for 50% growth inhibition: 9800 nM
Beside the measured number, compound 3's estimate is 1.0-fold (0.01 log units) above it; the range from low to high includes it.
By their numbers in this assay, from the lowest: compounds 3 and 2 (each within the scatter of the next); then compound 1.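

At the position next to the ring nitrogen, the open butyl chain and the thiophen-3-yl ring could not be told apart in this assay (a 1.4-fold lower number from compound 2 to compound 3 (0.13 log units; within the scatter)). The earlier step concerned only the isopropyl group elsewhere on the shared core, whereas this one shows that replacing butyl with a five-membered aromatic ring, which brings a sulfur atom and a hydrogen-bond acceptor that butyl lacks, leaves the number within the scatter here. Nothing available explains this result.

The compounds shown leave open whether a longer chain, an amine, a carboxylic acid or a thiophen-2-yl ring at this same position would move the number beyond the scatter. Among the compounds shown here, they also leave open whether removing isopropyl would have the same effect on a compound carrying thiophen-3-yl as it did on a compound carrying butyl, since no pair tests that change with this ring in place.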